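A few compounds are considered here, and "the series" means these few. Any claim that something is new, unique, unknown or untested is made for them only; others in the source may bear on it.

Compound 1 `Nc1ncnc2c1ncn2CC1CC1`: in a functional assay on the whole organism for antagonist activity, with Rattus norvegicus as the target (on this read-out lower numbers stand for an effect already at smaller amounts and higher numbers for an effect only at larger amounts of compound), compound 1 gives 20 mg/kg.
Compound 2 `c1nc(NC2CC2)c2ncn(CC3CC3)c2n1`: in this assay compound 2 gives 4 mg/kg.
Compound 3 `CN(c1ncnc2c1ncn2CC1CC1)C1CC1`: in this assay compound 3 gives 7.5 mg/kg.

Compound 2 shows the lowest number of the three in this assay, though one of its gaps is only a 1.9-fold higher number from compound 2 to compound 3 (0.27 log units; within the scatter), whereas the other is a 5.0-fold lower number from compound 1 to compound 2 (0.70 log units; beyond the scatter). Compound 4 `c1nc(NC2CC2)c2ncn(C3CCC3)c2n1` differs from compound 2 in one place: cyclobutyl in place of cyclopropylmethyl on an aromatic nitrogen. Among the measured compounds shown here, none of the measured steps touches that aromatic nitrogen. The steps of a 5.0-fold lower number from compound 1 to compound 2 (0.70 log units; beyond the scatter) and a 2.7-fold lower number from compound 1 to compound 3 (0.43 log units; beyond the scatter) both alter the amino group on the aromatic carbon, and a 1.9-fold higher number from compound 2 to compound 3 (0.27 log units; within the scatter) adds a methyl at the same site; all three leave the cyclopropylmethyl unchanged. So there is no measured guide for the group on the aromatic nitrogen, and the two structures keep the same atoms. Compound 4 is therefore expected to stay close to compound 2, with the step of a 1.3-fold higher number from compound 2 to compound 4 (0.10 log units; within the scatter) expected to fall within the usual scatter. For compound 4 the estimate in this assay is 5 mg/kg, with a range from 2 mg/kg to 12 mg/kg.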

Compound 4, dose for half-maximal effect: 19 mg/kg
The estimate for compound 4 lay 3.8-fold (0.58 log units) below the measured number; the measured number lies above the stated range.
By their numbers in this assay, from the lowest: compounds 2 and 3 (each within the scatter of the next); then compounds 4 and 1 (each within the scatter of the next).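

Among the compounds shown here, the group on the aromatic nitrogen, untouched by the earlier steps, turns out to matter in this assay: replacing cyclopropylmethyl with cyclobutyl gives a 4.8-fold higher number from compound 2 to compound 4 (0.68 log units; beyond the scatter) even though the two structures keep the same atoms. The change only rearranges the carbons, from a three-membered ring on a side chain to a four-membered ring, and neither group has any hydrogen-bond donors or acceptors, so matching atom content does not make these groups interchangeable here. This step lies beyond the scatter, as does a 5.0-fold lower number from compound 1 to compound 2 (0.70 log units; beyond the scatter) at the amino group, so both places affect the read-out. No available evidence accounts for the difference between the two groups.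

Going by these compounds, it remains open how a cyclopentyl group or a longer chain such as n-butyl would behave on this nitrogen. Also open, on these data alone, is whether the cyclobutyl step would carry over to the cyclopropyl(methyl)amino compound 3.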